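Chloro to nitro on the piperazine aryl, cytotoxicity series

A few compounds are considered here, and "the series" means these few. Any claim that something is new, unique, unknown or untested is made for them only; others in the source may bear on it.

Of the compounds shown here, three of one series have been measured in an ADME assay on Vero cells (Chlorocebus sabaeus) for cytotoxicity, read by resazurin assay, with a stated time of 72 h; on this read-out lower numbers stand for stronger inhibition and higher numbers for weaker inhibition. Compound 1 `COc1ccc(C(=O)CCN2CCN(c3ccc(Cl)cc3)CC2)cc1` gives 300000 nM. Compound 2 `COc1ccc(C(=O)CCN2CCN(c3ccc([N+](=O)[O-])cc3)CC2)cc1` gives 587000 nM. Compound 3 `O=C(CCN1CCN(c2ccc(Cl)cc2)CC1)c1ccc(Cl)c(F)c1` gives 175000 nM.

Compound 1 and compound 2 differ by nitro in place of chloro on an aromatic carbon, and the step of a 2.0-fold higher number from compound 1 to compound 2 (0.29 log units; within the scatter). Compound 1 and compound 3 differ in the core, by 4-chloro-3-fluorophenyl in place of 4-methoxyphenyl on a carbonyl carbon, and the step of a 1.7-fold lower number from compound 1 to compound 3 (0.23 log units; within the scatter). Compound 3 against compound 2 stands apart beyond the scatter, the only gap among the three that does.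

Compound 4 `O=C(CCN1CCN(c2ccc([N+](=O)[O-])cc2)CC1)c1ccc(Cl)c(F)c1` has not yet been measured. It differs from compound 3 by nitro in place of chloro on an aromatic carbon, which is the same change as between compound 1 and compound 2, at a place described in the same words. The core of compound 3 and compound 4, as set out under the counted difference above, is the only thing that separates this pair from the first.

Expected for compound 4 is a step of a 2.0-fold higher number from compound 3 to compound 4 (0.30 log units; within the scatter), because a 2.0-fold higher number from compound 1 to compound 2 (0.29 log units; within the scatter) for the same change at a place described in the same words. Among the measured compounds shown here, the estimate for compound 4 in this assay is 350000 nM, with a range from 150000 nM to 800000 nM, the width reflecting that only a single earlier step of this kind exists, on a different core.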

Compound 4, half-maximal inhibitory concentration: 89200 nM
Compound 4: the middle estimate sits 3.9-fold (0.59 log units) above what was measured; the measured number lies below the stated range.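

In this assay, nitro in place of chloro on the core of compound 3 gives a 2.0-fold lower number from compound 3 to compound 4 (0.29 log units; within the scatter), which alone cannot be told from scatter, yet set beside the same change on the core of compound 1 it does not carry over as one fixed step: the same change on two cores in this assay, a 2.0-fold higher number (0.29 log units; within the scatter) from compound 1 to compound 2 and a 2.0-fold lower number (0.29 log units; within the scatter) from compound 3 to compound 4, 3.8-fold (0.58 log units) apart, beyond the scatter of two such steps. With nitro present, 4-chloro-3-fluorophenyl in place of 4-methoxyphenyl on a carbonyl carbon gives a 6.6-fold lower number from compound 2 to compound 4 (0.82 log units; beyond the scatter), and this step does not match its counterpart with chloro present: the same change on two cores in this assay, a 1.7-fold lower number (0.23 log units; within the scatter) from compound 1 to compound 3 and a 6.6-fold lower number (0.82 log units; beyond the scatter) from compound 2 to compound 4, 3.8-fold (0.58 log units) apart, beyond the scatter of two such steps. The two changes therefore do not add up across compounds 1 to 4, but this rests on a single set of four compounds, the two comparisons are one gap read from two sides, and nothing here gives a reason for the gap or a rule for any other core.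

Going by these compounds, whether the same mismatch appears with another group in place of the nitro, such as a nitrile or an amine, remains open. Also open, on these data alone, is whether it persists on a core with another aryl group on the carbonyl carbon, or with a longer chain leading away from the carbonyl.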